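Chloro for bromo in two dithiolane-triazole coumarin amides

This account rests on a few compounds, and the source may have more. Where it says the series, first, only, none or still open, it means among the compounds named here.

Compound 1 `O=C(CCCCC1CCSS1)NCc1cn(CCCOc2ccc3cc(-c4ccc(Br)cc4)c(=O)oc3c2)nn1`: in a functional assay on PC-12 cells (Rattus norvegicus) for cytotoxicity, read by MTT assay, with stated times of 3 h and 2 h, tested at 10 uM (a lower number here means a weaker effect, a higher number a stronger effect of the compound at the concentration tested), compound 1 gives 63.3%.
Compound 2 `O=C(CCCCC1CCSS1)NCc1cn(CCCOc2ccc3cc(-c4ccc(Cl)cc4)c(=O)oc3c2)nn1`: in this assay compound 2 gives 67.8%.
Compound 3 `O=C(CCCCC1CCSS1)NCc1cn(CCCCOc2ccc3cc(-c4ccc(Br)cc4)c(=O)oc3c2)nn1`: in this assay compound 3 gives 42.6%.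

Compound 2 differs from compound 1 by one change, (chloro in place of bromo on an aromatic carbon), and this change made a step of a number 4.5 percentage points higher from compound 1 to compound 2 (within the scatter). Compound 3 rests on a different core; the difference between the two cores is not broken down here, so only the values themselves show that compound 3 lies lowest of the three. Compound 4 `O=C(CCCCC1CCSS1)NCc1cn(CCCCOc2ccc3cc(-c4ccc(Cl)cc4)c(=O)oc3c2)nn1` differs from compound 3 by chloro in place of bromo on an aromatic carbon; the place of the change is the same as before, so it is the same change. Because the earlier step of a number 4.5 percentage points higher from compound 1 to compound 2 (within the scatter) stayed within the scatter, a step of similar size is expected here, a number 4.4 percentage points higher from compound 3 to compound 4 (within the scatter). Compound 4 is therefore estimated at 47%, expected to fall between 35% and 60%.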

Compound 4, a percentage reported as activity, at one concentration (the size of the read-out at that concentration, not a potency): 61.8%
Beside the measured number, compound 4's estimate is 14.8 percentage points below it; measured number above the stated range.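

In this assay, the change from 4-bromophenyl to 4-chlorophenyl gave a number 19.2 percentage points higher from compound 3 to compound 4 (beyond the scatter). The size of the step did not carry over from one core to the other: the same change on two cores in this assay, a number 4.5 percentage points higher (within the scatter) from compound 1 to compound 2 and a number 19.2 percentage points higher (beyond the scatter) from compound 3 to compound 4, 14.7 percentage points apart, beyond the scatter of two such steps These two pairs show that the effect of this change depends on the core within this small set, but they do not show which feature of the cores sets its size, nor what the step would be on any further core.

On these data alone, it remains open how a fluoro or a methoxy group would behave on the same aromatic carbon. As far as these compounds go, it is also open whether a longer chain in the core would give a step closer to either of these two.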